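The compounds below may be only part of what the source reports. "The series", "measured", "known", "first", "only" and "open" are said of these compounds alone.

Working notes on the series in a functional assay (aorta) with Rattus norvegicus as the target; a higher number here means that more compound is needed for the effect, a lower number that less compound is needed. Compound 1 (`CN(C)/C(=N\C#N)C1=CC(C)(C)Oc2ccc(S(=O)(=O)c3ccccc3)cc21`) gives 3310 nM, while compound 2 (`CN(C)/C(=N\C#N)C1=CC(C)(C)Oc2ccc(C(F)(F)F)cc21`) gives 12600 nM, the higher of the two actual numbers. Compound 3 (`CN(C)/C(=N\C#N)C1=CC(C)(C)Oc2ccc(Cl)cc21`) reads > 31600 nM, which is a limit of the assay and not a number.

The open step leads to compound 4 (`CN(C)/C(=N\C#N)C1=CC(C)(C)Oc2ccccc21`), with hydrogen in place of trifluoromethyl on an aromatic carbon. Three measured replacements on an aromatic carbon bear on it: a 3.8-fold higher number from compound 1 to compound 2 (0.58 log units; beyond the scatter), an at least 9.5-fold higher number from compound 1 to compound 3 (0.97 log units; beyond the scatter) and an at least 2.5-fold higher number from compound 2 to compound 3 (0.39 log units; beyond the scatter). Among the measured compounds shown here, all three lie beyond the scatter and run towards higher numbers, and none of the measured compounds goes against that direction. The last step, which also starts from compound 2, is the closest guide, so a modest rise is expected. The expected step is a 2.8-fold higher number from compound 2 to compound 4 (0.44 log units; beyond the scatter). A report of compound 4 only as a limit is also expected to be likely, given (the limit of > 31600 nM in this assay, at which 1 of the 3 values shown sits). For compound 4 the estimated value is 35000 nM, with an expected range of 15000 nM to 100000 nM.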

Compound 4, half-maximal effective concentration: > 31600 nM
Compound 4 gave a limit, no number; the forecaster's own chance of this, stated with the estimate: 65%; the middle value is on the limit's open side.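

In this assay compound 4 reads > 31600 nM, a limit of the assay and not a number. Among the compounds shown here, with hydrogen on this aromatic carbon the series shows an at least 2.5-fold higher number from compound 2 to compound 4 (0.39 log units; beyond the scatter) and an at least 9.5-fold higher number from compound 1 to compound 4 (0.97 log units; beyond the scatter), so trifluoromethyl and phenylsulfonyl each need less compound than the bare position, which the earlier compounds, all carrying a group here, could not show. The step between compound 3 and compound 4 cannot be read, since both stop at the same limit: the limit of > 31600 nM in this assay, at which 2 of the 4 values shown sit.

Going by these compounds, whether chloro differs from hydrogen at all therefore stays open. Also open, on these data alone, is where a group such as an amine, a carboxylic acid or a methylsulfonyl would fall relative to phenylsulfonyl on this carbon, and whether any group here would need less compound than phenylsulfonyl.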